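Dimethyl substitution on the fused ring of a pyrazolone series

A few compounds are considered here, and "the series" means these few. Any claim that something is new, unique, unknown or untested is made for them only; others in the source may bear on it.

Three compounds of this series have been run in an assay on isolated protein for inhibition of alpha-ketoglutarate-dependent dioxygenase alkB homolog 3 (Homo sapiens), read by polymerase chain reaction, with a stated time of 1 h; on this read-out lower numbers stand for stronger inhibition and higher numbers for weaker inhibition. Compound 1 `Cc1[nH]n(-c2nc3c(C)cccc3[nH]2)c(=O)c1Cc1ccccc1` gives 5900 nM. Compound 2 `Cc1ccc2[nH]c(-n3[nH]c(C)c(Cc4ccccc4)c3=O)nc2c1` gives 670 nM, and compound 3 `Cc1[nH]n(-c2nc3cc(C(C)(C)C)ccc3[nH]2)c(=O)c1Cc1ccccc1` gives 640 nM. Compound 2 therefore stands second highest of the three numbers; it is closest to compound 3, and compound 1 stands furthest from it, with the higher number of the two.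

Within the data shown here, the only single-point step among the measured compounds is a 1.0-fold lower number from compound 2 to compound 3 (0.02 log units; within the scatter), which shows that enlarging the substituent at that aromatic carbon leaves the read-out essentially unchanged. Among the measured compounds shown here, compound 1 and compound 2 differ in where the single methyl sits on the fused ring, and no step is computed for that pair; their two values simply show a higher number for compound 1.

The next compound, compound 4 `Cc1ccc2[nH]c(-n3[nH]c(C)c(Cc4ccccc4)c3=O)nc2c1C`, carries methyl in place of hydrogen on an aromatic carbon. For the measured compounds named here, the step from compound 2 to compound 3 bears on it only loosely, since it concerns a change at a different aromatic carbon, but it is the nearest precedent and it was flat. Going by the values given here, no measured step reports the effect of a second methyl on this ring. The expectation for compound 4 is accordingly a step of a 1.0-fold higher number from compound 2 to compound 4 (0.02 log units; within the scatter) in this assay, not beyond the scatter, with an estimate of 700 nM and a range from 250 nM to 2000 nM.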

Compound 4, half-maximal inhibitory concentration: > 10000 nM
Compound 4: only a limit was reported (the forecaster's own chance of this, stated with the estimate: 3%); middle value at least 14-fold (1.15 log units) away from the limit.
By their numbers in this assay, from the lowest: compounds 3 and 2 (each within the scatter of the next); then compound 1. At a limit, above all of these: compound 4.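

Methyl in place of hydrogen on this aromatic carbon, ortho to a fused ring and ortho to a methyl group, is far from neutral in this assay: where the earlier change at another aromatic carbon gave a 1.0-fold lower number from compound 2 to compound 3 (0.02 log units; within the scatter), this single added carbon gives an at least 14-fold higher number from compound 2 to compound 4 (1.17 log units; beyond the scatter). Among these compounds, compound 4 is reported only as a limit of the assay, > 10000 nM, and it is the only compound of the series to reach it: the limit of > 10000 nM in this assay, at which 1 of the 4 values shown sits. The same methyl read from the other side gives an at least 1.6-fold higher number from compound 1 to compound 4 (0.22 log units; that floor lies within the scatter), so the series shows a large loss relative to compound 2, but relative to compound 1 the size of any loss remains unsettled.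

From the compounds shown here alone, how far the true value of compound 4 lies past its limit stays open, and with it the real size of both steps. Also open, going by these compounds, is whether the loss at this aromatic carbon is particular to methyl, or whether a fluorine, a methoxy group or an aminomethyl group there would give the same read-out.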